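A few compounds are considered here, and "the series" means these few. Any claim that something is new, unique, unknown or untested is made for them only; others in the source may bear on it.

Measured compounds in an assay on cells with melanin-concentrating hormone receptor 1 (Homo sapiens) as the target, read by radioligand binding; on this read-out lower numbers stand for stronger inhibition and higher numbers for weaker inhibition:
compound 1, `COCCOCCOc1cccc2ccc(N)nc12`: > 2000 nM
compound 2, `CC1CCCCC1Oc1cccc2ccc(N)nc12`: 32 nM
compound 3, `CC(C)Oc1cccc2ccc(N)nc12`: 437 nM

Of the two actual numbers shown, compound 3 holds the higher one, well apart from compound 2. Compound 1 yields no number at all, only a limit of the assay, (the limit of > 2000 nM in this assay, at which 1 of the 3 values shown sits). Compound 4, `CCOCC(C)Oc1cccc2ccc(N)nc12`, is still unmeasured; it differs from compound 3 by ethoxy in place of hydrogen on a saturated chain carbon, two bonds along the chain from an oxygen on an aromatic ring. Within the data shown here, no measured pair shows this exact change, so the size of the step is uncertain. Compound 1, carrying a longer ether chain, gives only a limit, while compound 2, with its saturated ring, gives the lower number. The step of a 1.8-fold higher number from compound 3 to compound 4 (0.26 log units; within the scatter) is therefore expected to be small, leaning toward a weaker result. Compound 4 is estimated at 800 nM, within roughly 250 nM to 2500 nM.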

Compound 4, half-maximal inhibitory concentration: 1070 nM
The estimate for compound 4 lay 1.3-fold (0.13 log units) below the measured number, within the range that was stated.
By their numbers in this assay, from the lowest: compound 2; then compound 3; then compound 4. At a limit, above all of these: compound 1.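

In this assay, among these compounds, the one step measured at this position is a 2.4-fold higher number from compound 3 to compound 4 (0.39 log units; beyond the scatter), so ethoxy in place of hydrogen on this saturated chain carbon weakens the result modestly without removing it. Compound 4 still gives a real number, so an ether group at this carbon is compatible with measurable inhibition. Compound 1 gives only a limit of the assay: the limit of > 2000 nM in this assay, at which 1 of the 4 values shown sits.

As far as these compounds go, whether a hydroxyl, an amine or a propyl group on this carbon would give a similar step remains open. The compounds shown also cannot say whether the oxygen of ethoxy matters to the step.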